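A Second Methyl on the Core of Compound 3

A few compounds are considered here, and "the series" means these few. Any claim that something is new, unique, unknown or untested is made for them only; others in the source may bear on it.

In a functional assay on the whole organism (strain Wistar) for inhibition, with Rattus norvegicus as the target, read by paw edema, with stated times of 1 h and 3 h, at a dose of 200 mg/kg by the oral route (a lower number here means less inhibition, a higher number more inhibition at the dose given (going by the name of the read-out)), compound 1 `COc1ccc(C2(O)/C(=C/c3ccccc3)CCCC2CN(C)c2ccccc2)cc1` gives 38.3%.
In this assay compound 2 `COc1ccc(C2(O)/C(=C/c3ccccc3)CCCC2CN(C)c2ccc(C)cc2)cc1` gives 21.3%.
In this assay compound 3 `COc1ccc(C2(O)/C(=C/c3ccc(C)cc3)CCCC2CN(C)c2ccccc2)cc1` gives 17%.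

Compound 3 holds the lowest of the three numbers, with compound 2 within the scatter of it and compound 1 beyond it. Compound 4 `COc1ccc(C2(O)/C(=C/c3ccc(C)cc3)CCCC2CN(C)c2ccc(C)cc2)cc1` differs from compound 3 in one place: methyl in place of hydrogen on an aromatic carbon. The two measured steps bear directly on this, since each adds one methyl to compound 1 on a different aromatic carbon: a number 17 percentage points lower from compound 1 to compound 2 (beyond the scatter) and a number 21.3 percentage points lower from compound 1 to compound 3 (beyond the scatter). Both single methyls lowered inhibition in this assay by a modest amount beyond the scatter. Compound 4 carries both methyls at once, so a further fall is the natural expectation, although the number for compound 3 already leaves little room below it, and nothing here shows whether two methyls together act as their sum. Compound 4 is therefore estimated at 9%, in a range of 0% to 20%. That estimate means an expected step of a number 8 percentage points lower from compound 3 to compound 4 (within the scatter), downward but possibly within the scatter.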

Compound 4, a percentage reported as inhibition, in the whole organism at one dose (the size of the read-out at that dose, not a potency): 29.8%
The estimate for compound 4 lay 20.8 percentage points below the measured number; the measured number lies above the stated range.
By their numbers in this assay, from the lowest: compounds 3, 2, 4 and 1 (each within the scatter of the next, the first and the last beyond it).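

In this assay, changing methyl(phenyl)amino to methyl(4-methylphenyl)amino gives a number 12.8 percentage points higher from compound 3 to compound 4 (beyond the scatter) when the other methyl is already present, so the direction of this change depends on the core: the same change on two cores in this assay, a number 17 percentage points lower (beyond the scatter) from compound 1 to compound 2 and a number 12.8 percentage points higher (beyond the scatter) from compound 3 to compound 4, 29.8 percentage points apart, beyond the scatter of two such steps
The other aromatic methyl gives a number 8.5 percentage points higher from compound 2 to compound 4 (within the scatter), so the fall it brought on the core of compound 1 does not recur here: the same change on two cores in this assay, a number 21.3 percentage points lower (beyond the scatter) from compound 1 to compound 3 and a number 8.5 percentage points higher (within the scatter) from compound 2 to compound 4, 29.8 percentage points apart, beyond the scatter of two such steps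
Going by these compounds alone, the effect of each methyl thus depends on whether the other is present, which no single step among the earlier compounds could show.

The compounds shown leave open whether an ethyl group, a chlorine or an amine in that place would depend on the core in the same way. With only one dose in this assay, they also leave open whether this dependence would hold at other doses.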